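The source may hold more compounds than are shown below. What is called first, only, known or untested is meant among the compounds shown, and "the series" means these compounds.

Measured so far in a functional assay on MCF7 cells (Homo sapiens) for inhibition, read by sulforhodamine B assay, with a stated time of 48 h; a higher number here means a weaker inhibitor of growth, a lower number a stronger inhibitor of growth:
compound 1 `CC1=CC[C@H](C(C)(C)NC(=S)N/N=C/c2ccccc2O)CC1` — 2200 nM
compound 2 `CC1=CC[C@H](C(C)(C)NC(=S)N/N=C/c2ccccc2Cl)CC1` — 11000 nM

Among the compounds with values here, compound 2 gives the highest number of the two; its nearest neighbour is compound 1, and the one step in hand, a 5.0-fold higher number from compound 1 to compound 2 (0.70 log units; beyond the scatter), separates them. Compound 2 is thus the weaker of the two growth inhibitors on the shared core.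

Compound 3 `CC1=CC[C@H](C(C)(C)NC(=S)N/N=C/c2ccccc2[N+](=O)[O-])CC1` has not been measured. It differs from compound 2 by nitro in place of chloro on an aromatic carbon, on an aromatic carbon of a six-membered aromatic ring of carbon only, ortho to a large group.

Within the data shown here, no measured step bears directly on nitro in place of chloro at this position. Among the measured compounds shown here, the only step known, a 5.0-fold higher number from compound 1 to compound 2 (0.70 log units; beyond the scatter), concerns hydroxy against chloro and shows that the substituent on this ring moves the number by a modest amount; it gives no direction for nitro. The step from compound 2 to compound 3 is therefore expected to be small and of uncertain sign, a 1.4-fold lower number from compound 2 to compound 3 (0.14 log units; within the scatter). For compound 3 the expected value in this assay is 8000 nM, with a range from 2500 nM to 25000 nM.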

Compound 3, concentration for 50% growth inhibition: 1200 nM
Compound 3: the middle estimate sits 6.7-fold (0.82 log units) above what was measured; the whole stated range lies above it.
By their numbers in this assay, from the lowest: compounds 3 and 1 (each within the scatter of the next); then compound 2.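

In this assay, the aromatic carbon ortho to a large group now has a measured direction for nitro in place of chloro, a 9.2-fold lower number from compound 2 to compound 3 (0.96 log units; beyond the scatter), a change beyond the scatter. Nitro and hydroxy are not separated at this carbon, with a 1.8-fold lower number from compound 1 to compound 3 (0.26 log units; within the scatter) lying within the scatter, so among these three compounds it is chloro that stands apart, with compound 2 above both compound 1 and compound 3 by steps beyond the scatter. No measurement in hand accounts for chloro standing apart from the other two groups.

On these data alone, whether an amine or a methoxy group on this same aromatic carbon would fall with compound 1 and compound 3 or with compound 2 remains open, and three substituents cannot show whether any broader trend exists. The compounds shown also differ in this one place only, so it is unknown whether the same order would hold with a nitro, hydroxy or chloro group elsewhere on the ring or with a change at another part of the shared core.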